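A few compounds are considered here, and "the series" means these few. Any claim that something is new, unique, unknown or untested is made for them only; others in the source may bear on it.

Measured compounds:
- compound 1, `C=COc1cncc(N2CCNCC2)c1`: 7590 nM
- compound 2, `c1ccc2ncc(N3CCCNCC3)cc2c1`: 3630 nM
- compound 3, `COc1cc(N2CCNCC2)cnc1Br`: 17000 nM

In a functional assay on HEK293 cells for agonist activity at Neuronal acetylcholine receptor; alpha4/beta2 (Homo sapiens), read by FLIPR and calcium flux (a higher number here means that more compound is needed for the effect, a lower number that less compound is needed), compound 1 gives 7590 nM, compound 2 gives 3630 nM, and compound 3 gives 17000 nM. Compound 3 therefore stands highest of the three numbers; its nearest neighbour is compound 1, and that gap is already beyond the scatter, while the gap to compound 2 is wider still. Compound 4, `Brc1ccc(N2CCNCC2)cn1`, differs from compound 3 in a single place: hydrogen in place of methoxy on an aromatic carbon. For the measured compounds named here, no measured pair shows what removing a methoxy does here, so the direction of the step is open. The three measured compounds differ in several places at once, and none of them isolates the methoxy. The author expects for this assay a step from compound 3 to compound 4 of a 1.4-fold lower number from compound 3 to compound 4 (0.15 log units; within the scatter), that is, a small change that may not exceed the scatter. The estimate for compound 4 in this assay is 12000 nM, with a range from 4000 nM to 36000 nM.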

Compound 4, half-maximal effective concentration: 2510 nM
The estimate for compound 4 lay 4.8-fold (0.68 log units) above the measured number, and the stated range ends above it.
By their numbers in this assay, from the lowest: compounds 4 and 2 (each within the scatter of the next); then compound 1; then compound 3.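

In this assay, the change of hydrogen in place of methoxy on an aromatic carbon, ortho to a bromo group and two atoms from the ring nitrogen, gives a 6.8-fold lower number from compound 3 to compound 4 (0.83 log units; beyond the scatter). For the compounds shown here, this is the first comparison in the set that isolates a single place, and it shows that the methoxy at this position is not needed for the effect, since less compound is needed without it. Nothing measured here bears on why the number moves.

The compounds shown leave open whether any group at this place raises the number or only the methoxy does, which a fluoro, a methyl or an amine there would test. They also leave open whether the step would hold without the bromo group.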